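Carbamate series: extending the sulfur-linked aryl chain

The source may report more compounds than this note shows. Statements on the series, on what has been measured and on what is new or still open speak of the compounds shown alone.

Compound 2 `CC(C)c1cccc(C(C)C)c1OC(=O)NC(=O)SCCc1ccccc1` gives 880 nM in an assay on microsomes from intestine for inhibition of acyl-CoA:cholesterol acyltransferase (Oryctolagus cuniculus); on this read-out higher numbers stand for weaker inhibition and lower numbers for stronger inhibition. Among the two compounds measured so far it carries the highest number; its nearest neighbour, compound 1 `CC(C)c1cccc(C(C)C)c1OC(=O)NC(=O)SCc1ccco1`, gives 470 nM, and the step of a 1.9-fold higher number from compound 1 to compound 2 (0.27 log units; within the scatter) lies within the scatter. Compound 3 `CC(C)c1cccc(C(C)C)c1OC(=O)NC(=O)SCCCc1ccccc1` has not been measured. It differs from compound 2 by benzyl in place of phenyl on a saturated chain carbon, two bonds along the chain from a sulfur; cut one bond further out, the same difference reads phenethyl to 3-phenylpropyl. Within the data shown here, no measured step covers exactly this change. Among the measured compounds shown here, the only step available, a 1.9-fold higher number from compound 1 to compound 2 (0.27 log units; within the scatter), also lengthens the saturated chain between the sulfur and the aromatic ring, but at the same time exchanges furan-2-yl for benzyl, so it bears on the present change only in part, and it was small. A step of similar size is therefore expected in this assay, towards a higher number if anything, and not clearly beyond the scatter. Compound 3 is expected to give 1100 nM (range 400 nM to 3000 nM). This amounts to an expected 1.3-fold higher number from compound 2 to compound 3 (0.10 log units; within the scatter).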

Compound 3, half-maximal inhibitory concentration: 69 nM
Compound 3: the middle estimate sits 16-fold (1.20 log units) above what was measured; the measured number lies below the stated range.
By their numbers in this assay, from the lowest: compound 3; then compounds 1 and 2 (each within the scatter of the next).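

In this assay, the chain on the sulfur proves sensitive to a single added unit: phenethyl to 3-phenylpropyl, read as benzyl in place of phenyl on a saturated chain carbon, two bonds along the chain from a sulfur, gives a 13-fold lower number from compound 2 to compound 3 (1.11 log units; beyond the scatter), against only a 1.9-fold higher number from compound 1 to compound 2 (0.27 log units; within the scatter) for the earlier step, which also exchanged furan-2-yl for a phenyl ring. Compound 3 also separates clearly from the furan-2-yl compound, with a 6.8-fold lower number from compound 1 to compound 3 (0.83 log units; beyond the scatter), which makes it the strongest inhibitor of the three, so across these compounds the response to chain length is an abrupt drop at 3-phenylpropyl and not a gradual trend. Nothing in hand accounts for the size of this step.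

As far as these compounds go, whether the number keeps falling with a longer chain such as 4-phenylbutyl, or rises again, remains open. Also open, from the compounds shown here alone, is whether the phenyl ring at the chain end is needed at all, which a plain alkyl chain, or a chain ending in an amine or a carboxylic acid, would address.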